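From 3-nitrophenyl to 4-chlorophenyl: notes on compound 3

The source may report more compounds than this note shows. Statements on the series, on what has been measured and on what is new or still open speak of the compounds shown alone.

Of the compounds shown here, two have numbers so far. In a functional assay on MCF7 cells (Homo sapiens) for cytotoxicity, read by MTT assay, with a stated time of 48 h (on this read-out higher numbers stand for weaker inhibition and lower numbers for stronger inhibition), compound 1 (`C=C1CCC[C@]2(C)CCC(C=O)=CC[C@@]12C`) gives 319000 nM. Compound 2 (`C=C1CCC[C@]2(C)CCC(c3cn(-c4cccc([N+](=O)[O-])c4)nn3)=CC[C@@]12C`) gives 40300 nM in this assay, the lower of the two numbers, and the gap to compound 1 lies beyond the scatter.

Within the data shown here, compound 3 (`C=C1CCC[C@]2(C)CCC(c3cn(-c4ccc(Cl)cc4)nn3)=CC[C@@]12C`) has no measurement yet. It differs from compound 2 in one place, with 4-chlorophenyl in place of 3-nitrophenyl on an aromatic nitrogen. Among the measured compounds shown here, no measured pair differs in one place, so the series offers no direct precedent for this exchange in this assay. No step beyond the scatter is expected, in either direction, and that expectation rests on little data. The estimated change is a 1.1-fold lower number from compound 2 to compound 3 (0.05 log units; within the scatter). For compound 3 the expected value is 36000 nM, with an estimated range of 14000 nM to 90000 nM.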

Compound 3, half-maximal inhibitory concentration: 35100 nM
Estimate against measurement, compound 3: 1.0-fold (0.01 log units) above; the range from low to high includes it.
By their numbers in this assay, from the lowest: compounds 3 and 2 (each within the scatter of the next); then compound 1.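

In this assay, among these compounds, the first one-place exchange, on an aromatic nitrogen of the five-membered aromatic ring, gives a step within the scatter (a 1.1-fold lower number from compound 2 to compound 3 (0.06 log units; within the scatter)). This position therefore accepts 4-chlorophenyl as well as 3-nitrophenyl with no step beyond the scatter, even though the entering group has no hydrogen-bond acceptors and no double bond outside the aromatic ring. Nothing measured here offers an explanation for this result.

This pair alters the substituent and its place on the phenyl ring together, and 3-chlorophenyl or 4-nitrophenyl would be needed to read each alone. From the compounds shown here alone, it also remains open whether an amine or a carboxylic acid on the phenyl ring, or a longer chain on this nitrogen, would give a step beyond the scatter.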